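Compound 3: an oxadiazole exchange after two limit values

A few compounds are considered here, and "the series" means these few. Any claim that something is new, unique, unknown or untested is made for them only; others in the source may bear on it.

Measured so far in an ADME assay (liver) for metabolic stability, with Liver microsome (Rattus norvegicus) as the target, using microsomes; on this read-out higher numbers stand for a longer-lived compound and lower numbers for a shorter-lived compound:
- compound 1 `CS(=O)(=O)c1cnc(O[C@H]2CC[C@H](OC3CCN(CC4(C(F)(F)F)CC4)CC3)CC2)cn1`: > 1 h
- compound 2 `CC(C)c1noc(CN2CCC(O[C@H]3CC[C@H](Oc4cnc(S(C)(=O)=O)cn4)CC3)CC2)n1`: > 1 h

Compound 2 stands at > 1 h, which is a limit of the assay and not a number. Compound 1 also gives only a limit, > 1 h. All the evidence so far is the limit of > 1 h in this assay, at which 2 of the 2 values shown sit.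

Compound 3 `CC(F)Cc1nc(CN2CCC(O[C@H]3CC[C@H](Oc4cnc(S(C)(=O)=O)cn4)CC3)CC2)no1` departs from compound 2 on a saturated chain carbon bound to an amine nitrogen in a ring, where 5-(2-fluoropropyl)-1,2,4-oxadiazol-3-yl takes the place of 3-isopropyl-1,2,4-oxadiazol-5-yl: 5-(2-fluoropropyl)-1,2,4-oxadiazol-3-yl in place of 3-isopropyl-1,2,4-oxadiazol-5-yl on a saturated chain carbon bound to an amine nitrogen in a ring.

Among the compounds with values here, only one measured step bears on this change, and it also concerns the group on that carbon. It is a step that the two limits leave unreadable from compound 1 to compound 2, so it gives no size to carry over. Within the data shown here, no measured step points in either direction in this assay, and no step beyond the scatter is expected. The expected change is a step that the limit leaves unreadable from compound 2 to compound 3.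

For compound 3 the estimated half-life is 1.2 h, with an expected range from 0.6 h to 2.5 h. A further report of only a limit is expected to be the likeliest outcome.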

Compound 3, half-life: > 1 h
Compound 3: only a limit was reported; the forecaster's own chance of this, stated with the estimate: 70%; the middle value is on the limit's open side.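

In this assay compound 3 gives > 1 h, which is a limit of the assay and not a number. No step among compound 1, compound 2 and compound 3 can be read, because the evidence stands as follows: the limit of > 1 h in this assay, at which 3 of the 3 values shown sit.

As far as these compounds go, how far apart the half-lives of these three compounds lie, and in which order, remains open.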